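The source may report more compounds than this note shows. Statements on the series, on what has been measured and on what is new or still open speak of the compounds shown alone.

Of the compounds shown here, three with a shared core have been tested in a functional assay on ACHN cells (Homo sapiens) for antiproliferative activity, read by sulforhodamine B assay; a lower number here means a stronger inhibitor of growth, a higher number a weaker inhibitor of growth. Here compound 3 `CC(C)COc1cccc(O)c1C(=O)/C=C/c1ccc(O)cc1` gives 3290 nM, and compound 1 `CC(C)CCCOc1cccc(O)c1C(=O)/C=C/c1ccc(O)cc1` gives 3630 nM. These two stand level, with a 1.1-fold lower number from compound 1 to compound 3 (0.04 log units; within the scatter). Compound 2 `CCCCCCOc1cccc(O)c1C(=O)/C=C/c1ccc(O)cc1` gives > 30000 nM, which is a limit.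

Compound 4 `O=C(/C=C/c1ccc(O)cc1)c1c(O)cccc1OCCC1CCCC1` alters only the side chain of compound 3: cyclopentylmethyl in place of isopropyl on a saturated chain carbon bound to an oxygen on an aromatic ring. In words, cyclopentylmethyl takes the place of isopropyl on a saturated chain carbon bound to an oxygen on an aromatic ring.

Two kinds of measured step bear on this. Lengthening a branched chain made no real difference, as a 1.1-fold lower number from compound 1 to compound 3 (0.04 log units; within the scatter) shows. Losing the branch at the chain end mattered, with an at least 8.2-fold higher number from compound 1 to compound 2 (0.91 log units; beyond the scatter) and an at least 9.1-fold lower number from compound 2 to compound 3 (0.95 log units; beyond the scatter). The chain of compound 4 also ends in a branching point, here a ring, so no step beyond the scatter is the likeliest outcome, although a rise cannot be excluded given the result for compound 2.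

In this assay the expected step is a 1.1-fold higher number from compound 3 to compound 4 (0.03 log units; within the scatter). For compound 4 the estimated value is 3500 nM, with an expected range from 1300 nM to 12000 nM.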

Compound 4, concentration for 50% growth inhibition: 3400 nM
Compound 4: middle estimate off by 1.0-fold (0.01 log units), on the high side, and the stated range covers the measured number.
By their numbers in this assay, from the lowest: compounds 3, 4 and 1 (each within the scatter of the next). At a limit, above all of these: compound 2.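

Compound 4 shows that this position, a saturated chain carbon bound to an oxygen on an aromatic ring, accepts a carbon ring as well as an open branch in this assay: there is a 1.0-fold higher number from compound 3 to compound 4 (0.01 log units; within the scatter), and a 1.1-fold lower number from compound 1 to compound 4 (0.03 log units; within the scatter). Only the straight chain stands apart, with an at least 8.8-fold lower number from compound 2 to compound 4 (0.94 log units; beyond the scatter). That step starts from a number that is a limit, so its true size cannot be read: the limit of > 30000 nM in this assay, at which 1 of the 4 values shown sits.

The compounds shown leave open whether a chain ending in a cyclohexyl or phenyl ring, an amine or a carboxylic acid would stay level with compounds 1, 3 and 4. They also cannot tell why the straight chain of compound 2 stands apart while the branched and ring-ended chains do not.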